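The compounds below may be only part of what the source reports. "The series", "measured", "known", "first", "only" and "open" are said of these compounds alone.

Measured so far:
compound 1 `COc1ccc(OC)c(N2C(=O)CSC2c2cccc(C(=O)NCCCCc3ccccc3)c2)c1` — 5%
compound 2 `O=C(NCCCCc1ccccc1)c1cccc(C2SCC(=O)N2c2ccccc2)c1` — 55%

In a functional assay on HOS cells (Homo sapiens) for inhibition, read by CCK-8 assay, with a stated time of 72 h, tested at 1 uM (on this read-out lower numbers stand for less inhibition and higher numbers for more inhibition at the one concentration tested (going by the name of the read-out)), compound 2 gives 55%, the highest of the two numbers; its nearest neighbour is compound 1, which gives 5%. Among the measured compounds shown here, the one measured step, a number 50 percentage points higher from compound 1 to compound 2 (beyond the scatter), is large and beyond the scatter.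

Compound 3 `COc1cc(F)ccc1N1C(=O)CSC1c1cccc(C(=O)NCCCCc2ccccc2)c1` differs from compound 2 by 4-fluoro-2-methoxyphenyl in place of phenyl on an amide-type nitrogen in a ring. For the measured compounds named here, the only step that bears on this change is a number 50 percentage points higher from compound 1 to compound 2 (beyond the scatter), where a substituted phenyl on the amide-type nitrogen in the ring gave way to plain phenyl and the number rose sharply. Compound 3 moves back toward a substituted phenyl at that nitrogen, though with a 4-fluoro-2-methoxyphenyl rather than 2,5-dimethoxyphenyl, so the size carried over is uncertain. A drop beyond the scatter is therefore expected. Compound 3 is estimated at 25%, within 5% to 50%, which means an expected step of a number 30 percentage points lower from compound 2 to compound 3 (beyond the scatter).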

Compound 3, a percentage reported as inhibition, at one concentration (the size of the read-out at that concentration, not a potency): 81%
Estimate against measurement, compound 3: 56 percentage points below, outside the stated range (above it).
By their numbers in this assay, from the lowest: compound 1; then compound 2; then compound 3.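

In this assay, a substituted phenyl on the amide-type nitrogen in the ring does not by itself bring the number down: a number 26 percentage points higher from compound 2 to compound 3 (beyond the scatter), so the pattern suggested by a number 50 percentage points higher from compound 1 to compound 2 (beyond the scatter) does not hold for every substituted phenyl at this position. The two substituted groups themselves lie far apart, a number 76 percentage points higher from compound 1 to compound 3 (beyond the scatter), so at this nitrogen the read-out turns on which substituted phenyl is present, with 4-fluoro-2-methoxyphenyl giving the highest number of the three compounds and 2,5-dimethoxyphenyl the lowest. No measurement on hand accounts for this difference.

The compounds shown do not separate the contribution of the fluoro substituent from that of the methoxy substituent in compound 3. Also open, from the compounds shown here alone, is how an amine or a carboxylic acid on this phenyl would read, and whether the result carries over to a longer chain on the side amide.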